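Lengthening the chain in the methylpiperazine series

This account rests on a few compounds, and the source may have more. Where it says the series, first, only, none or still open, it means among the compounds named here.

Compound 1 `CCCN1CCN(CCCCn2c3c(c4ccccc42)C(=O)c2c[n+]([O-])c4ccccc4c2C3=O)CC1`: 1280 nM
Compound 2 `CN1CCN(CCCn2c3c(c4ccccc42)C(=O)c2c[n+]([O-])c4ccccc4c2C3=O)CC1`: 220 nM
Compound 3 `CN1CCN(CCCCCn2c3c(c4ccccc42)C(=O)c2c[n+]([O-])c4ccccc4c2C3=O)CC1`: not yet measured

In a functional assay on MCF7 cells (Homo sapiens) for cytotoxicity, read by MTT assay, with a stated time of 72 h (a higher number here means a weaker inhibitor, a lower number a stronger inhibitor), compound 2 holds the lower of the two numbers, at 220 nM. The change to compound 3 is 2-(4-methylpiperazin-1-yl)ethyl in place of 4-methylpiperazin-1-yl on a saturated chain carbon, three bonds along the chain from an aromatic nitrogen. Going by the values given here, one measured step bears on it: a 5.8-fold lower number from compound 1 to compound 2 (0.76 log units; beyond the scatter). That step also replaces the propyl of 4-propylpiperazin-1-yl with a methyl, so it is only a partial guide. A modest rise in the number in this assay is therefore expected, and the expected step is a 2.2-fold higher number from compound 2 to compound 3 (0.34 log units; beyond the scatter). For compound 3 the estimated value is 480 nM, with an expected range of 170 nM to 1300 nM.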

Compound 3, half-maximal inhibitory concentration: 1260 nM
The estimate for compound 3 lay 2.6-fold (0.42 log units) below the measured number; the measured number falls inside the stated range.
By their numbers in this assay, from the lowest: compound 2; then compounds 3 and 1 (each within the scatter of the next).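

In this assay, going by these compounds alone, 2-(4-methylpiperazin-1-yl)ethyl in place of 4-methylpiperazin-1-yl gives a 5.7-fold higher number from compound 2 to compound 3 (0.76 log units; beyond the scatter), the only step here that changes chain length while keeping the methyl on the piperazine. Across the other pair, (4-methylpiperazin-1-yl)methyl in place of 4-propylpiperazin-1-yl gives a 1.0-fold lower number from compound 1 to compound 3 (0.01 log units; within the scatter), so these two chain and substituent combinations are not separated in this assay. No available evidence accounts for either step.

The compounds shown leave open whether a shorter chain would keep the number of compound 2. From the compounds shown here alone, a morpholine in place of the methylpiperazine also remains untested in this set.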